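The compounds below may be only part of what the source reports. "The series", "measured", "known", "first", "only" and "open" are said of these compounds alone.

Measured in a functional assay on L1210/0 cells (Mus musculus) for antiproliferative activity, read by MTT assay, with a stated time of 72 h; a lower number here means a stronger inhibitor, a higher number a weaker inhibitor:
- compound 1 `O=C1O/C(=C\Cn2cnc3c(F)nc(F)c(Cl)c32)C(OCc2ccccc2)=C1OCc1ccccc1` gives "not determined" (no result reported)
- compound 2 `O=C1NC(O)(CCn2cnc3cncc(Br)c32)C(OCc2ccccc2)=C1OCc1ccccc1` gives 50000 nM

Compound 1 offers no number as a starting point, so compound 2 at 50000 nM is the only anchor in this assay for this series. Compound 3 `O=C1O/C(=C\Cn2cnc3ncc(Br)c-3c2)C(OCc2ccccc2)=C1OCc1ccccc1` departs from compound 1 by one change: a group of 10 heavy atoms (6 carbon, 3 nitrogen, 1 bromine; one five-membered aromatic ring with 1 hetero atom, one six-membered aromatic ring with 2 hetero atoms) in place of a group of 12 heavy atoms (6 carbon, 3 nitrogen, 2 fluorine, 1 chlorine; one five-membered aromatic ring with 2 hetero atoms, one six-membered aromatic ring with 1 hetero atom), on a saturated chain carbon bound to a double-bonded chain carbon is the whole difference. Among the measured compounds shown here, no measured step shows what such a swap does, so its size and direction from compound 1 remain open. A modest gain over compound 2 at 50000 nM is expected. The estimate for compound 3 is 12000 nM as the expected value, with 2500 nM to 50000 nM as its expected range.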

Compound 3, half-maximal inhibitory concentration: 15000 nM
The estimate for compound 3 lay 1.3-fold (0.10 log units) below the measured number; the range from low to high includes it.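

Among the compounds shown here, compound 1 carries no number in this assay so no step to compound 3 can be read. From the compounds shown here alone, what the exchange of groups on the saturated chain carbon does to activity stays open. No evidence bearing on this result is available.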